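From methylsulfanyl to hydroxy on the aryl ether

The source may hold more compounds than are shown below. What is called first, only, known or untested is meant among the compounds shown, and "the series" means these compounds.

In a functional assay for inhibition, with Homo sapiens as the target (on this read-out lower numbers stand for tighter binding and higher numbers for weaker binding), compound 2 (`CSc1ccccc1OC(C)(C)C1OCC(C/C=C\CCC(=O)O)C(c2cccnc2)O1`) gives 89.1 nM as the higher of two numbers, against compound 1 (`Cc1ccc(C#N)c(OC(C)(C)C2OCC(C/C=C\CCC(=O)O)C(c3cccnc3)O2)c1`) at 15.9 nM on the same read-out. Compound 3 (`CC(C)(Oc1ccccc1O)C1OCC(C/C=C\CCC(=O)O)C(c2cccnc2)O1`) carries hydroxy in place of methylsulfanyl on an aromatic carbon. For the measured compounds named here, the one measured step on this aryl group is a 5.6-fold higher number from compound 1 to compound 2 (0.75 log units; beyond the scatter) and it is modest. In this assay a step of no greater size is therefore expected, tentatively towards a lower number, since the data do not settle its direction. The estimated change is a 2.2-fold lower number from compound 2 to compound 3 (0.35 log units; beyond the scatter) at the centre of the range. For compound 3 the expected value is 40 nM (range 10 nM to 160 nM).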

Compound 3, dissociation constant: 95.5 nM
The estimate for compound 3 lay 2.4-fold (0.38 log units) below the measured number; the range from low to high includes it.
By their numbers in this assay, from the lowest: compound 1; then compounds 2 and 3 (each within the scatter of the next).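

Exchanging methylsulfanyl for hydroxy on this aromatic carbon in this assay gives no readable difference (a 1.1-fold higher number from compound 2 to compound 3 (0.03 log units; within the scatter)), even though hydroxy brings a hydrogen-bond donor that methylsulfanyl lacks. The 2-hydroxyphenyl group, like 2-(methylsulfanyl)phenyl, stays apart from 2-cyano-5-methylphenyl (a 6.0-fold higher number from compound 1 to compound 3 (0.78 log units; beyond the scatter)). No supporting measurement bears on this result.

Going by these compounds, whether a methoxy or an amine on this carbon would read the same remains open. So does whether the cyano or the methyl group of 2-cyano-5-methylphenyl accounts for the gap.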